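The source may report more compounds than this note shows. Statements on the series, on what has been measured and on what is new or still open speak of the compounds shown alone.

Two compounds of this series have a number in a functional assay on MCF7 cells (Homo sapiens) for inhibition, read by MTT assay, with a stated time of 72 h; a lower number here means a stronger inhibitor, a higher number a weaker inhibitor. Compound 1 `C#CCSc1nc(Nc2ccccc2Cl)c(C#N)c(-c2ccccc2)n1` gives 24200 nM. Compound 2 `Cc1ccc(Nc2nc(SCc3cn(Cc4ccccc4Cl)nn3)nc(-c3ccc(C)cc3)c2C#N)cc1` gives 30900 nM; this is the higher of the two numbers, but the gap to compound 1 lies within the usual scatter, so the two values show no difference that can be read. Among the compounds with values here, compounds 1 and 2 differ in several places, and no single step between them can be drawn from the structures.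

Compound 3 `Cc1ccc(Nc2nc(SCc3cn(Cc4ccccc4Cl)nn3)nc(-c3ccc(Br)cc3)c2C#N)cc1` is not yet measured. It differs from compound 2 by bromo in place of methyl on an aromatic carbon. Within the data shown here, no measured pair isolates a change of this kind, so the direction of the step from compound 2 to compound 3 is not fixed by any number in hand; the expectation is a step of a 1.2-fold lower number from compound 2 to compound 3 (0.07 log units; within the scatter), that is, none beyond the scatter, resting only on compound 2 at 30900 nM. For compound 3 the estimate in this assay is 26000 nM, expected between 8000 nM and 80000 nM.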

Compound 3, half-maximal inhibitory concentration: 25100 nM
For compound 3 the middle estimate is 1.0-fold (0.02 log units) above the measured one, and the stated range covers the measured number.
By their numbers in this assay, from the lowest: compounds 1, 3 and 2 (each within the scatter of the next).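

In this assay, within the data shown here, the change from 4-methylphenyl to 4-bromophenyl is the only single-place step available so far, giving a 1.2-fold lower number from compound 2 to compound 3 (0.09 log units; within the scatter) for this swap. At this position, on an aromatic carbon para to a large group, bromo in place of methyl therefore gives no difference that can be read, and compound 2 and compound 3 remain indistinguishable in this measurement. No measured evidence on hand bears on the reason for this result.

Going by these compounds, what an amine, a carboxylic acid or a longer chain at this position would do to the number remains open. Also open, on these data alone, is whether bromo in place of methyl would read the same way at another place on the shared core.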